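Benzothiazolyl aminopyrimidines: antiproliferative readings and a nitro analogue

A few compounds are considered here, and "the series" means these few. Any claim that something is new, unique, unknown or untested is made for them only; others in the source may bear on it.

Measured so far in a functional assay on MCF7 cells (Homo sapiens) for antiproliferative activity, read by MTT assay, with a stated time of 48 h; a lower number here means a stronger inhibitor, a higher number a weaker inhibitor:
Compound 1 `Cc1cnc(Nc2ccc(C(C)C)cc2)nc1Nc1nc2ccccc2s1` — compound 1 reaches only the assay limit, > 50000 nM.
Compound 2 `NS(=O)(=O)c1ccc(Nc2ncc(F)c(Nc3nc4ccccc4s3)n2)cc1` — compound 2 likewise sits at a limit, > 50000 nM.
Compound 3 `CS(=O)(=O)c1ccc(Nc2nccc(Nc3nc4ccc(F)cc4s3)n2)cc1` — compound 3 sits at a limit, > 60000 nM.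

Compound 1 therefore stands at the limit of > 50000 nM in this assay, at which 2 of the 3 values shown sit; the remaining reading sits at the limit of > 60000 nM in this assay, at which 1 of the 3 values shown sits. Going by the values given here, none of the three readings is a number, so no ordering among the compounds is possible. Compound 4 `Cc1cnc(Nc2ccc([N+](=O)[O-])cc2)nc1Nc1nc2ccccc2s1` carries nitro in place of isopropyl on an aromatic carbon. Among the compounds with values here, no measured pair shows what this change does, so no direction beyond the scatter can be claimed for it. Compound 4 is expected to remain near the limit, a step that the limit leaves unreadable from compound 1 to compound 4. The estimate for compound 4 in this assay is 60000 nM, with a range from 20000 nM to 200000 nM.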

Compound 4, half-maximal inhibitory concentration: > 50000 nM
Compound 4 was reported as a limit; the forecaster's own chance of this, stated with the estimate: 75%; the middle value lies beyond the limit too.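

Compound 1 and compound 4 both sit at assay limits, so nitro in place of isopropyl gives no readable step. The compounds shown leave open which change to the shared core, if any, would give a numeric reading.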